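Adding a chloro to the phenyl group of compound 3

The source may hold more compounds than are shown below. What is called first, only, known or untested is meant among the compounds shown, and "the series" means these compounds.

In a functional assay on U-87MG ATCC cells for antiproliferative activity against U-87 MG (Homo sapiens), read by MTT assay, with a stated time of 48 h (on this read-out higher numbers stand for weaker inhibition and lower numbers for stronger inhibition), compound 3 (`Cc1nc(-c2ccccc2)sc1C(=O)CSc1nc(N)c(C#N)c(-c2ccc(Cl)cc2)n1`) gives 10800 nM and sits within the scatter of compound 1 (`COc1ccc(-c2nc(SCC(=O)c3sc(-c4ccccc4)nc3C)nc(N)c2C#N)cc1`), which gives 14000 nM on the same read-out. Compound 2 (`COc1ccc(-c2nc(C)c(C(=O)CSc3nc(N)c(C#N)c(-c4ccc(Cl)cc4)n3)s2)cc1`) gives 4540 nM and lies apart from both, with a 2.4-fold higher number from compound 2 to compound 3 (0.38 log units; beyond the scatter) on removing its methoxy.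

Compound 4 (`Cc1nc(-c2ccc(Cl)cc2)sc1C(=O)CSc1nc(N)c(C#N)c(-c2ccc(Cl)cc2)n1`) differs from compound 3 in one place: chloro in place of hydrogen on an aromatic carbon in all, chloro in place of hydrogen on an aromatic carbon, so phenyl becomes 4-chlorophenyl.

Among the measured compounds shown here, two measured steps bear on this. The step to compound 3 from compound 2 changes this same phenyl group, and shows that a substituent there can shift the number modestly. Elsewhere in the molecule, a 1.3-fold lower number from compound 1 to compound 3 (0.11 log units; within the scatter) shows chloro standing in for methoxy without a change beyond the scatter. For the measured compounds named here, no measured step places chloro on this phenyl group, so the parallel is indirect.

A modest move towards a lower number is expected, with a 1.7-fold lower number from compound 3 to compound 4 (0.22 log units; within the scatter) as the estimated step. Compound 4 is estimated at 6500 nM in this assay, within a range of 2800 nM to 13000 nM as expected limits.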

Compound 4, half-maximal inhibitory concentration: 3420 nM
For compound 4 the middle estimate is 1.9-fold (0.28 log units) above the measured one; low and high end bracket the measured number.
By their numbers in this assay, from the lowest: compounds 4 and 2 (each within the scatter of the next); then compounds 3 and 1 (each within the scatter of the next).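

In this assay a chloro on this phenyl group produces a step beyond the scatter (a 3.2-fold lower number from compound 3 to compound 4 (0.50 log units; beyond the scatter)), the first direct sign that a chloro at this place lowers the number. The chloro and the methoxy at this place cannot be told apart (a 1.3-fold lower number from compound 2 to compound 4 (0.12 log units; within the scatter)), so the two substituents tried on this phenyl group land within the scatter of each other. The same exchange of methoxy for chloro also changes little on the other aromatic ring, so in both cases shown the two groups behave alike: the same change on two cores in this assay, a 1.3-fold lower number (0.11 log units; within the scatter) from compound 1 to compound 3 and a 1.3-fold lower number (0.12 log units; within the scatter) from compound 2 to compound 4, 1.0-fold (0.01 log units) apart, within the scatter of two such steps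

As far as these compounds go, what remains open is whether other groups on the same carbon, such as a fluoro, an amine or a carboxylic acid, would also lower the number. From the compounds shown here alone, it is also open whether the step from hydrogen to chloro would repeat on a core carrying methoxy on its other aromatic ring, as in compound 1.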